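The source may hold more compounds than are shown below. What is called first, only, known or untested is meant among the compounds shown, and "the series" means these compounds.

Measured in an ADME assay on microsomes from liver (Mus musculus, strain CD-1) for metabolic stability, read by LC-MS, with a stated time of 60 min, tested at 20 uM; on this read-out higher numbers stand for a longer-lived compound and lower numbers for a shorter-lived compound:
compound 1 `O=c1c2cn(C3COC3)nc2nc(SCc2cccc(F)c2)n1-c1ccccc1`: 0.383 h
compound 2 `COc1cccc(C(C)Sc2nc3c(cnn3C)c(=O)n2-c2ccccc2)c1`: 0.1 h
compound 3 `CC(Sc1nc2c(cnn2C)c(=O)n1-c1ccccc1)c1ccccc1`: 0.133 h

Compound 3 stands second of the three numbers; its value and that of compound 2 lie within the scatter of each other, while compound 1 gives a clearly higher number than compound 3. Within the data shown here, the one step between measured compounds, a 1.3-fold higher number from compound 2 to compound 3 (0.12 log units; within the scatter), came from a hydrogen in place of methoxy on an aromatic carbon. Compound 4 `C[C@@H](Sc1nc2c(cnn2C)c(=O)n1-c1ccccc1)c1ccccc1` differs from compound 3 in this way: the two compounds have the same atoms and bonds; at least one stereo element is drawn with a configuration in one of them and without one in the other: 1 of 1 stereo elements differ; a stereocentre at a saturated chain carbon is drawn without a configuration in compound 3 and R in compound 4. No measured step concerns a stereocentre, so nothing among these compounds shows how the two configurations separate in this assay. The step of a 1.0-fold lower number from compound 3 to compound 4 (0.01 log units; within the scatter) is therefore expected to stay within the scatter. For compound 4 in this assay the estimate is 0.13 h, with a range of 0.07 h to 0.27 h.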

Compound 4, half-life: 0.133 h
Estimate against measurement, compound 4: 1.0-fold (0.01 log units) below, and the stated range covers the measured number.
By their numbers in this assay, from the lowest: compounds 2, 3 and 4 (each within the scatter of the next); then compound 1.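

In this assay, among these compounds, drawing the R configuration at the saturated chain carbon gives no change at the digits printed from compound 3 to compound 4 (within the scatter) and so provides the first measured step at a stereocentre. On this read-out, the R drawing and the drawing without a configuration are not told apart at this position. The comparison rests on one difference alone: the fact that one of compounds 3 and 4 is drawn with a defined configuration and the other without, at the place where they differ

As far as these compounds go, how the S configuration reads at this carbon remains open. So does the outcome in this assay of an amine or a carboxylic acid on this chain carbon in place of methyl.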